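A few compounds are considered here, and "the series" means these few. Any claim that something is new, unique, unknown or untested is made for them only; others in the source may bear on it.

Measured compounds in an assay on microsomes from liver for inhibition of 3-hydroxy-3-methylglutaryl-coenzyme A reductase (Rattus norvegicus); on this read-out higher numbers stand for weaker inhibition and lower numbers for stronger inhibition:
compound 1, `CC(C)c1c(C(=O)NCc2ccccc2)nn(-c2ccc(F)cc2)c1OC[C@@H](O)C[C@@H](O)CC(=O)O`: 3.8 nM
compound 2, `Cc1ccc(CN(C)C(=O)c2nn(-c3ccc(F)cc3)c(OC[C@@H](O)C[C@@H](O)CC(=O)O)c2C(C)C)cc1`: 37 nM
compound 3, `Cc1ccc(CNC(=O)c2nn(-c3ccc(F)cc3)c(OC[C@@H](O)C[C@@H](O)CC(=O)O)c2C(C)C)cc1`: 15 nM

Compound 1 has the lowest number of the three in this assay, with compound 3 nearest to it and compound 2 furthest away. Compound 4, `COc1ccc(CNC(=O)c2nn(-c3ccc(F)cc3)c(OC[C@@H](O)C[C@@H](O)CC(=O)O)c2C(C)C)cc1`, differs from compound 1 in one place: methoxy in place of hydrogen on an aromatic carbon. For the measured compounds named here, only one measured step touches the same aromatic carbon: the change from hydrogen to methyl there gave a 3.9-fold higher number from compound 1 to compound 3 (0.60 log units; beyond the scatter), a modest weakening. The other two steps, a 9.7-fold higher number from compound 1 to compound 2 (0.99 log units; beyond the scatter) and a 2.5-fold lower number from compound 2 to compound 3 (0.39 log units; beyond the scatter), concern the amide-type nitrogen and so say little about this position. A methoxy group, like a methyl group, adds a small substituent at the same place, so a similar modest weakening is expected, that is a 3.2-fold higher number from compound 1 to compound 4 (0.50 log units; beyond the scatter). Compound 4 is therefore estimated at 12 nM in this assay, with a likely range from 4 nM to 35 nM.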

Compound 4, half-maximal inhibitory concentration: 12 nM
Compound 4: middle estimate and measured number agree at the digits printed; the range from low to high includes it.
By their numbers in this assay, from the lowest: compound 1; then compounds 4 and 3 (each within the scatter of the next); then compound 2.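

In this assay, methoxy on this aromatic carbon, para to a large group, also weakens inhibition compared with hydrogen (a 3.2-fold higher number from compound 1 to compound 4 (0.50 log units; beyond the scatter)), so this loss is not confined to methyl. Exchanging methyl for methoxy at this carbon leaves the two compounds within the scatter (a 1.3-fold lower number from compound 3 to compound 4 (0.10 log units; within the scatter)), and changing the whole amino group, with the amide hydrogen restored and methoxy in place of methyl, gives a clearer shift (a 3.1-fold lower number from compound 2 to compound 4 (0.49 log units; beyond the scatter)). No measurement shown explains why either group gives a higher number than hydrogen.

Still open, going by these compounds, is whether a fluorine atom, a hydroxyl group or an amine on this carbon would stay as close to compound 1 or move further away. On these data alone, the effect of a longer chain such as butoxy at this carbon also remains unknown.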